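The source may report more compounds than this note shows. Statements on the series, on what has been measured and on what is new or still open speak of the compounds shown alone.

Measured compounds in a functional assay on 4T1 cells (Mus musculus) for cytotoxicity, read by MTT assay, with a stated time of 24 h; a higher number here means a weaker inhibitor, a lower number a stronger inhibitor:
Compound 1 `O=C1/C(=C/c2ccccc2F)CN(C(=S)SCc2cn(Cc3ccccc3Cl)nn2)C/C1=C\c1ccccc1F` gives 43600 nM.
Compound 2 `O=C1/C(=C/c2ccccc2F)CN(C(=S)SCc2cn(Cc3ccc(F)cc3)nn2)C/C1=C\c1ccccc1F` gives 9900 nM.
Compound 3 `COc1ccc(/C=C2\CN(Cc3cn(Cc4ccc(F)cc4)nn3)C/C(=C\c3ccc(OC)cc3)C2=O)cc1` gives 49300 nM.

Compound 4 `COc1ccc(/C=C2\CN(Cc3cn(Cc4ccccc4Cl)nn3)C/C(=C\c3ccc(OC)cc3)C2=O)cc1` has not been measured. Compound 4 differs from compound 3 by 2-chlorophenyl in place of 4-fluorophenyl on a saturated chain carbon bound to an aromatic nitrogen. The same change, (2-chlorophenyl in place of 4-fluorophenyl on a saturated chain carbon bound to an aromatic nitrogen), occurs between compound 2 and compound 1, where it gave a step of a 4.4-fold higher number from compound 2 to compound 1 (0.64 log units; beyond the scatter). The cores of compound 2 and compound 3 differ, and that difference is not broken down here; compound 3 simply shows the higher of the two numbers. Compound 4 is expected to show a 2.4-fold higher number from compound 3 to compound 4 (0.39 log units; beyond the scatter) because the same change gave a 4.4-fold higher number from compound 2 to compound 1 (0.64 log units; beyond the scatter) on the other core, though the transfer to a new core is uncertain. For compound 4 the estimate is 120000 nM, within a range from 40000 nM to 400000 nM.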

Compound 4, half-maximal inhibitory concentration: 11400 nM
Compound 4: middle estimate off by 11-fold (1.02 log units), on the high side, and the stated range ends above it.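

In this assay, replacing 4-fluorobenzyl with 2-chlorobenzyl gave a 4.3-fold lower number from compound 3 to compound 4 (0.64 log units; beyond the scatter), opposite in direction to the step seen for the same change on the other core. The change therefore did not carry from one core to the other in this series, and the two steps clearly disagree: the same change on two cores in this assay, a 4.4-fold higher number (0.64 log units; beyond the scatter) from compound 2 to compound 1 and a 4.3-fold lower number (0.64 log units; beyond the scatter) from compound 3 to compound 4, 19-fold (1.28 log units) apart, beyond the scatter of two such steps This shows that the outcome of the change depends on the core, but it does not show which feature of the cores sets the direction, and one pair per core gives no rule for any further core.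

The compounds shown leave open whether a 2-fluorobenzyl or 4-chlorobenzyl group in the same place would reverse in the same way on the two cores. Also open, from the compounds shown here alone, is how an unsubstituted benzyl group would compare on either core.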